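Swapping chloro for fluoro on a weakly cytotoxic benzothiazole pair

This account rests on a few compounds, and the source may have more. Where it says the series, first, only, none or still open, it means among the compounds named here.

Measured so far in a functional assay on THP-1 cells (Homo sapiens) for cytotoxicity, read by MTT assay, with a stated time of 48 h; a higher number here means a weaker inhibitor, a lower number a stronger inhibitor:
- compound 1, `CCOc1ccc2nc(Nc3nc4ccc(F)cc4s3)sc2c1`, gives 39000 nM
- compound 2, `Cc1ccc2nc(Nc3nc4ccc(F)cc4s3)sc2c1`, gives > 50000 nM
- compound 3, `Fc1ccc2nc(Nc3nc4ccc(Cl)cc4s3)sc2c1`, gives 41000 nM

The value of compound 2 is a limit of this assay, not a number (the limit of > 50000 nM in this assay, at which 1 of the 3 values shown sits). Among the two numbers, compound 3 sits highest, with compound 1 nearest: the step is a 1.1-fold higher number from compound 1 to compound 3 (0.02 log units; within the scatter), so the two cannot be told apart. Compound 2 shows an at least 1.2-fold higher number from compound 1 to compound 2 (0.10 log units; that floor lies within the scatter) and an at least 1.2-fold lower number from compound 2 to compound 3 (0.08 log units; that floor lies within the scatter), which also do not rise above the scatter.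

Compound 4, `Fc1ccc2nc(Nc3nc4ccc(F)cc4s3)sc2c1`, is reached from compound 3 by one change: fluoro in place of chloro on an aromatic carbon. For the measured compounds named here, no measured pair here swaps these two halogens, so the bearing steps are only those on the same aromatic carbon, a 1.1-fold higher number from compound 1 to compound 3 (0.02 log units; within the scatter) and an at least 1.2-fold lower number from compound 2 to compound 3 (0.08 log units; that floor lies within the scatter). Every substituent tried there left the numbers within the scatter of one another, and all three compounds are weak in this assay.

The step from compound 3 to compound 4 is therefore expected to be small, a 1.1-fold higher number from compound 3 to compound 4 (0.04 log units; within the scatter), with no direction favoured. Compound 4 is estimated at 45000 nM, within a range from 20000 nM to 100000 nM.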

Compound 4, half-maximal inhibitory concentration: 17500 nM
Beside the measured number, compound 4's estimate is 2.6-fold (0.41 log units) above it; measured number outside the range, below it.
By their numbers in this assay, from the lowest: compound 4; then compounds 1 and 3 (each within the scatter of the next). At a limit, above all of these: compound 2.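

At this aromatic carbon the substituent can move the number in this assay after all: fluoro in place of chloro gives a 2.3-fold lower number from compound 3 to compound 4 (0.37 log units; beyond the scatter) as a modest step, whereas the earlier swaps among ethoxy, methyl and chloro never rose above the scatter. Fluoro also separates from ethoxy, with a 2.2-fold lower number from compound 1 to compound 4 (0.35 log units; beyond the scatter) as a step of similar size, which leaves compound 4 with the lowest number of the four and shows that this small swap of one halogen for another matters more here than the larger swap of chloro for ethoxy did. Compound 2 carries a limit of the assay and not a number, so its step to fluoro, an at least 2.8-fold lower number from compound 2 to compound 4 (0.45 log units; beyond the scatter) in the same direction, gives only a floor for the true gap: the limit of > 50000 nM in this assay, at which 1 of the 4 values shown sits.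

On these data alone, what an amine, a carboxylic acid or a longer chain would do on this same carbon stays open. As far as these compounds go, it is also open whether fluoro lowers the number on its own merit or only when the rest of the molecule carries fluoro too, and the numbers give no reason for the step.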